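This account rests on a few compounds, and the source may have more. Where it says the series, first, only, none or still open, it means among the compounds named here.

Series of chalcone-type compounds sharing the core of compound 1 `COc1ccc(C(=O)/C=C/c2cc3ccccc3[nH]c2=O)cc1`, tested in a functional assay on HOP-62 cells (Homo sapiens) for cytotoxicity, read by sulforhodamine B assay, with a stated time of 24 h; on this read-out higher numbers stand for weaker inhibition of growth and lower numbers for stronger inhibition of growth. Compound 1 gives 3680 nM. Compound 2 `O=C(/C=C/c1cc2ccccc2[nH]c1=O)c1ccc(O)cc1` gives 2620 nM, the lowest of the two numbers; the step of a 1.4-fold lower number from compound 1 to compound 2 (0.15 log units; within the scatter) lies within the scatter, so no order between the two is established. Compound 3 `O=C(/C=C/c1cc2ccccc2[nH]c1=O)c1ccc(Cl)cc1` carries chloro in place of hydroxy on an aromatic carbon. Among the compounds with values here, no measured step bears on this change; the only measured step concerns the oxygen substituent, not its replacement. Compound 3 is therefore expected to sit near compound 2, with a 1.0-fold lower number from compound 2 to compound 3 (0.02 log units; within the scatter), estimated at 2500 nM within 800 nM to 8000 nM.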

Compound 3, concentration for 50% growth inhibition: 7430 nM
Estimate against measurement, compound 3: 3.0-fold (0.47 log units) below; measured number inside the range.
By their numbers in this assay, from the lowest: compounds 2 and 1 (each within the scatter of the next); then compound 3.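

In this assay this position proves sensitive to the substituent, which the two oxygen groups alone did not show: chloro in place of hydroxy gives a 2.8-fold higher number from compound 2 to compound 3 (0.45 log units; beyond the scatter) and chloro in place of methoxy gives a 2.0-fold higher number from compound 1 to compound 3 (0.31 log units; beyond the scatter). Both steps run the same way and lie beyond the scatter, so chloro separates from both oxygen substituents even though these two do not separate from each other. Nothing available explains this difference.

Open, from the compounds shown here alone, is whether the higher number is specific to chloro or would also follow fluoro or methyl on this carbon. Also open, going by these compounds, is where an amine or a carboxylic acid at this position would fall.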